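Isobutoxy in place of isopropoxy on the aryl amide

This account rests on a few compounds, and the source may have more. Where it says the series, first, only, none or still open, it means among the compounds named here.

In an assay on cells for inhibition of IL15-IL15 receptor (Homo sapiens), read by AlphaScreen, with stated times of 30 min and 1 h (on this read-out higher numbers stand for weaker inhibition and lower numbers for stronger inhibition), compound 2 `CC(C)Oc1ccc(NC(=O)CCCCCCCSc2nnc(Cc3nn(C)c(=O)c4ccccc34)n2C)cc1` gives 93000 nM, and compound 1 `Cn1c(Cc2nn(C)c(=O)c3ccccc23)nnc1SCCCCCCCC(=O)Nc1ccc(F)cc1F` gives 110000 nM, so the two sit within the scatter of each other, as a 1.2-fold lower number from compound 1 to compound 2 (0.07 log units; within the scatter) shows. Compound 3 `CC(C)COc1ccc(NC(=O)CCCCCCCSc2nnc(Cc3nn(C)c(=O)c4ccccc34)n2C)cc1` differs from compound 2 by isobutyl in place of isopropyl on an oxygen on an aromatic ring. Going by the values given here, the only measured step, the aryl exchange from compound 1 to compound 2, stayed within the scatter, and the present change is smaller still, so no step beyond the scatter is expected in this assay. Compound 3 is therefore estimated at 90000 nM, between 40000 nM and 200000 nM, an expected step of a 1.0-fold lower number from compound 2 to compound 3 (0.01 log units; within the scatter).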

Compound 3, half-maximal inhibitory concentration: 55000 nM
Compound 3: middle estimate off by 1.6-fold (0.21 log units), on the high side, within the range that was stated.
By their numbers in this assay, from the lowest: compounds 3, 2 and 1 (each within the scatter of the next).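

Putting isobutyl in place of isopropyl on the oxygen, with no ring, hydrogen-bond donor or acceptor entering, gives a 1.7-fold lower number from compound 2 to compound 3 (0.23 log units; within the scatter) in this assay, so this position takes the extra carbon without a step beyond the scatter. Seen against the 2,4-difluorophenyl amide, the 4-(isobutoxy)phenyl group gives a 2.0-fold lower number from compound 1 to compound 3 (0.30 log units; within the scatter) and also stays within the scatter. Nothing at hand explains these numbers.

Still open, on these data alone, is whether a longer chain on this oxygen, or an amine or a carboxylic acid at its end, would move the number beyond the scatter.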